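The compounds below may be only part of what the source reports. "The series", "measured", "known", "first", "only" and "open" are said of these compounds alone.

For the measured compounds named here, in an ADME assay on microsomes from liver (Mus musculus) for metabolic stability, with a stated time of 10 min, tested at 0.5 uM (on this read-out lower numbers stand for a less stable compound and higher numbers for a more stable compound), compound 2 (`C[C@@H](NCc1ccc(Cl)cc1)[C@H]1CC[C@@H](c2ccnc3ccc(F)cc32)CC1`) gives 2%, the lowest of the three numbers measured so far. Compound 1 (`C[C@@H](CNc1ccc(Cl)cc1)[C@H]1CC[C@@H](c2ccnc3ccc(F)cc32)CC1`) gives 80%, and compound 3 (`C[C@@H](CNC(=O)c1ccc(Cl)cc1)[C@H]1CC[C@@H](c2ccnc3ccc(F)cc32)CC1`) gives 32%. The next compound, compound 4 (`C[C@@H](NC(=O)c1ccccc1Cl)[C@H]1CC[C@@H](c2ccnc3ccc(F)cc32)CC1`), has not yet been measured. It keeps the shared core of compound 2 but carries (2-chlorophenyl)carbonyl in place of 4-chlorobenzyl on an amine nitrogen.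

Going by the values given here, two measured steps bear on this change, and both are large: a number 78 percentage points lower from compound 1 to compound 2 (beyond the scatter), and a number 48 percentage points lower from compound 1 to compound 3 (beyond the scatter). The numbers in this series can therefore move a long way with a modest edit. Among the compounds with values here, compound 3 is the only measured compound with a carbonyl on an amine nitrogen, and its 32% stands well clear of the value of compound 2. Within the data shown here, no measured compound has the (2-chlorophenyl)carbonyl group itself, and compound 3 also differs from compound 4 in its chain, so this comparison is only a rough guide. A sizeable upward move is expected, and the estimated step is a number 28 percentage points higher from compound 2 to compound 4 (beyond the scatter). Compound 4 is expected to give about 30%, within an estimated range from 9% to 58%.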

Compound 4, percent of the compound remaining: 7%
For compound 4 the middle estimate is 23 percentage points above the measured one; the measured number lies below the stated range.
By their numbers in this assay, from the lowest: compounds 2 and 4 (each within the scatter of the next); then compound 3; then compound 1.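

In this assay, putting (2-chlorophenyl)carbonyl in place of 4-chlorobenzyl on this amine nitrogen gives a number 5 percentage points higher from compound 2 to compound 4 (within the scatter) and so leaves the two compounds without a readable difference. The earlier compounds shown here showed this series moving a long way with a modest edit, whereas this pair shows that an edit bringing in a carbonyl and a hydrogen-bond acceptor on the amine nitrogen need not shift the number beyond the usual scatter. No measurement shown here offers an explanation for this result.

The change alters two things at once, since the carbonyl enters while the chlorine also sits at a different ring place, so the compounds shown leave open what each alteration contributes on its own. A (4-chlorophenyl)carbonyl group or an unsubstituted phenylcarbonyl group on the same nitrogen would separate the two, and a sulfonyl group in place of the carbonyl would show whether another linking group at this nitrogen gives a number clear of the scatter.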